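The source may hold more compounds than are shown below. What is called first, only, known or untested is meant among the compounds shown, and "the series" means these compounds.

Measured in a functional assay on A549 cells (Homo sapiens) for inhibition, read by MTT assay, with a stated time of 72 h; a higher number here means a weaker inhibitor, a lower number a stronger inhibitor:
- compound 1 `C=C(Cl)C(=O)Nc1cc(Nc2nc3c(c(-c4cn(C)c5ccc(F)cc45)n2)CS(=O)(=O)CC3)c(OC)cc1N(C)CCN(C)C`: 3180 nM
- compound 2 `COc1cc(N(C)CCN(C)C)c(NC(=O)/C=C\C(C)C)cc1Nc1nc2c(c(-c3cn(C)c4ccc(F)cc34)n1)CS(=O)(=O)CC2`: 3750 nM

Only these two numbers are available so far, and compound 2, at 3750 nM, lies within the scatter of compound 1, so the two cannot be ranked. Compound 3 `CCC/C=C\C(=O)Nc1cc(Nc2nc3c(c(-c4cn(C)c5ccc(F)cc45)n2)CS(=O)(=O)CC3)c(OC)cc1N(C)CCN(C)C` differs from compound 2 at the end of one chain: propyl in place of isopropyl on a double-bonded chain carbon bound to a double-bonded chain carbon. Going by the values given here, one measured step bears on this, a 1.2-fold higher number from compound 1 to compound 2 (0.07 log units; within the scatter), where 3-methylbut-1-en-1-yl replaced 1-chloroethenyl on a carbonyl carbon. That step stayed within the scatter, so no change beyond the scatter is expected in this assay. The expected size is a 1.0-fold lower number from compound 2 to compound 3 (0.02 log units; within the scatter). The estimate for compound 3 is 3600 nM, with an expected range of 1700 nM to 7500 nM.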

Compound 3, half-maximal inhibitory concentration: 7570 nM
Estimate against measurement, compound 3: 2.1-fold (0.32 log units) below, outside the stated range (above it).
By their numbers in this assay, from the lowest: compounds 1 and 2 (each within the scatter of the next); then compound 3.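

In this assay, rearranging the same three carbons from isopropyl to propyl gives a 2.0-fold higher number from compound 2 to compound 3 (0.31 log units; beyond the scatter), so this end of the chain is sensitive to how its carbons are joined, even though the atoms themselves stay the same. The comparison with the chloro compound now also changes: 3-methylbut-1-en-1-yl stayed within the scatter of 1-chloroethenyl, whereas pent-1-en-1-yl gives a 2.4-fold higher number from compound 1 to compound 3 (0.38 log units; beyond the scatter), so not every replacement of 1-chloroethenyl at this carbonyl carbon is tolerated equally. Nothing available explains why the straight chain gives the weaker result.

On these data alone, it remains open whether a longer chain such as butyl would push the number higher still, or how an amine such as dimethylamino would behave at this place. A single isopropyl and propyl pair also cannot show whether the difference would hold on another core.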